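Shortening the Side Chain on the Shared Core

The source may hold more compounds than are shown below. What is called first, only, known or untested is meant among the compounds shown, and "the series" means these compounds.

Within the data shown here, compound 3 `CCCCSc1nc(N)c2nc(O)n(Cc3ccccc3)c2n1` gives 0.01 uM in a functional assay (spleen, spleen) for activation, with Mus musculus as the target (on this read-out lower numbers stand for an effect already at smaller amounts and higher numbers for an effect only at larger amounts of compound), the lowest of the three numbers measured so far. Compound 2 `Nc1nc(SCc2ccccc2)nc2c1nc(O)n2Cc1ccccc1` gives 0.1 uM in this assay, and compound 1 `CNc1nc(N)c2nc(O)n(Cc3ccccc3)c2n1` gives 1 uM. Compound 4 `CCc1nc(N)c2nc(O)n(Cc3ccccc3)c2n1` differs from compound 3 in one place: ethyl in place of butylsulfanyl on an aromatic carbon. Among the measured compounds shown here, two measured steps bear on this change. The step of a 100-fold lower number from compound 1 to compound 3 (2.00 log units; beyond the scatter) shows how far the butylsulfanyl group moved the number, and a 10-fold lower number from compound 2 to compound 3 (1.00 log units; beyond the scatter) shows that the chain carried on the sulfur also matters. For the measured compounds named here, no measured step removes the sulfur or shortens the chain this much, so a weaker effect is expected, with an estimated step of a 30-fold higher number from compound 3 to compound 4 (1.48 log units; beyond the scatter). Compound 4 is therefore expected to give 0.3 uM in this assay, within a range from 0.03 uM to 3 uM.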

Compound 4, minimum effective concentration: 1 uM
Estimate against measurement, compound 4: 3.3-fold (0.52 log units) below; low and high end bracket the measured number.
By their numbers in this assay, from the lowest: compound 3; then compound 2; then compounds 1 and 4 (each within the scatter of the next).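

Taking the sulfur-linked chain off this aromatic carbon costs a great deal in this assay, since ethyl in place of butylsulfanyl gives a 100-fold higher number from compound 3 to compound 4 (2.00 log units; beyond the scatter). Ethyl also falls short of the benzylsulfanyl group, with a 10-fold higher number from compound 2 to compound 4 (1.00 log units; beyond the scatter), while ethyl and methylamino cannot be told apart, with no change at the digits printed from compound 1 to compound 4 (within the scatter). Nothing measured here explains why both sulfur-linked groups give lower numbers than ethyl. The compounds shown leave open whether the sulfur or the length of the chain counts for more. A butoxy group or a pentyl chain on this carbon would help separate the two.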